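Trimming an ethyl group in a hydrazone cytotoxicity series

A few compounds are considered here, and "the series" means these few. Any claim that something is new, unique, unknown or untested is made for them only; others in the source may bear on it.

Compound 2 `CCOc1ccc(/C=N/NC(=O)c2cnccn2)cc1` was tested in an ADME assay on J774 cells (Mus musculus) for cytotoxicity, read by MTT assay, with a stated time of 48 h, tested at 100 ug/mL (on this read-out lower numbers stand for a stronger effect and higher numbers for a weaker effect at the one concentration tested), where compound 2 gives 98%. Within the data shown here, of the two compounds measured so far it stands highest; its only neighbour is compound 1 `O=C(N/N=C/c1ccc(Cl)cc1)c1cnccn1`, which in this assay gives 64%. Among the measured compounds shown here, the step of a number 34 percentage points higher from compound 1 to compound 2 (beyond the scatter) is the one measured change in the set, and it exchanges chloro for ethoxy.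

Compound 3 `O=C(N/N=C/c1ccc(O)cc1)c1cnccn1` has not been measured yet. Its change from compound 2 is hydrogen in place of ethyl on an oxygen on an aromatic ring. For the measured compounds named here, no measured step touches the same place: the step from compound 1 to compound 2 altered what sits on the aromatic carbon, not on the oxygen, so it shows only that this end of the molecule can move the read-out a great deal. Going by the values given here, with compound 2 already at the top of the measured numbers, any move in this assay for compound 3 is more likely downward than upward, but no measured pair says how far. The expected step is a number 13 percentage points lower from compound 2 to compound 3 (beyond the scatter). Compound 3 is therefore estimated at 85%, with a range from 55% to 100%.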

Compound 3, a percentage reported as activity, at one concentration (the size of the read-out at that concentration, not a potency): 81%
Estimate against measurement, compound 3: 4 percentage points above; low and high end bracket the measured number.
By their numbers in this assay, from the lowest: compound 1; then compound 3; then compound 2.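

Taking the ethyl off the oxygen, which turns ethoxy into hydroxy, gives a number 17 percentage points lower from compound 2 to compound 3 (beyond the scatter) in this assay, so the group on the oxygen moves this read-out by itself, and the change need not replace the whole substituent on the aromatic carbon to have an effect. Hydroxy in place of chloro on the aromatic carbon gives a number 17 percentage points higher from compound 1 to compound 3 (beyond the scatter), so a free hydroxy also stands higher than chloro, though not as high as ethoxy, and the three groups now form a clear order from chloro through hydroxy to ethoxy, with each gap beyond the usual scatter. Nothing measured alongside these numbers accounts for that order, so the data describe the size of these changes and give no reason for them.

On these data alone, with only hydroxy and ethoxy as oxygen-linked groups, it remains open whether methoxy would land with hydroxy or with ethoxy, and whether a longer chain such as propoxy would behave like ethoxy. As far as these compounds go, it is equally open where an amine or a carboxylic acid on the same aromatic carbon would fall in this order.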